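Cyclohexyl in place of 3-methoxyphenyl on the shared core

The compounds below may be only part of what the source reports. "The series", "measured", "known", "first", "only" and "open" are said of these compounds alone.

Of the compounds shown here, three on a shared core have been measured in a functional assay on HeLa cells (Homo sapiens) for inhibition, read by sulforhodamine B assay; a lower number here means a stronger inhibitor, a higher number a weaker inhibitor. Compound 1 `O=C1C(Nc2ccccc2)=CC(=O)c2c1nc1n2[C@H]2OC[C@@H](O)[C@H]2OC1` gives > 8000 nM, which is a limit of the assay. Among the measured compounds shown here, compound 2 `Cc1ccc(NC2=CC(=O)c3c(nc4n3[C@H]3OC[C@@H](O)[C@H]3OC4)C2=O)cc1` gives 6590 nM, the one true number in the set. Compound 3 `COc1cccc(NC2=CC(=O)c3c(nc4n3[C@H]3OC[C@@H](O)[C@H]3OC4)C2=O)c1` gives > 8000 nM, again a limit and not a number. Compound 3 thus stands at the limit of > 8000 nM in this assay, at which 2 of the 3 values shown sit.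

Compound 4 `O=C1C(NC2CCCCC2)=CC(=O)c2c1nc1n2[C@H]2OC[C@@H](O)[C@H]2OC1` carries cyclohexyl in place of 3-methoxyphenyl on an amine nitrogen, a difference that counts as cyclohexyl in place of 3-methoxyphenyl on an amine nitrogen. The measured steps that bear on this change all stay among aromatic groups on that nitrogen. Methyl in place of hydrogen gives an at least 1.2-fold lower number from compound 1 to compound 2 (0.08 log units; that floor lies within the scatter). Exchanging the 4-methylphenyl for 3-methoxyphenyl gives an at least 1.2-fold higher number from compound 2 to compound 3 (0.08 log units; that floor lies within the scatter). Methoxy in place of hydrogen gives a step that the two limits leave unreadable from compound 1 to compound 3. For the measured compounds named here, no measured compound has a non-aromatic ring at this place, so the size of such a change is not known from these data. With no measured step shown beyond the scatter, no clear move in either direction is expected, and compound 4 is expected to stay close to the limit. The estimated result is a step that the limit leaves unreadable from compound 3 to compound 4. For compound 4 the estimated value is 9000 nM, with an expected range from 3500 nM to 20000 nM.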

Compound 4, half-maximal inhibitory concentration: > 16000 nM
Compound 4: only a limit was reported; the forecaster's own chance of this, stated with the estimate: 65%; at least 1.7-fold (0.24 log units) between middle value and limit.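

In this assay, among the compounds shown here, moving to a non-aromatic ring on the amine nitrogen gives the first step at this position that lies beyond the scatter, with cyclohexyl in place of 4-methylphenyl producing an at least 2.4-fold higher number from compound 2 to compound 4 (0.38 log units; beyond the scatter). On these data alone, compound 4 reads as a limit and not a number, which makes this step a floor whose full size stays unknown: the limit of > 16000 nM in this assay, at which 1 of the 4 values shown sits. The steps to compound 4 from compound 1 and from compound 3 cannot be read, because each of them joins two limits: the limit of > 8000 nM in this assay, at which 2 of the 4 values shown sit.

As far as these compounds go, whether this loss belongs to cyclohexyl alone or to non-aromatic groups on this nitrogen more widely stays open, and a cyclopropyl ring, an open butyl chain or a piperidine ring would help to settle it. For the compounds shown here, also open is whether any aromatic group can bring the number clearly down, as compound 2 gives 6590 nM and is the only compound here with a true number, so a chloro, hydroxy or amino group on the phenyl ring would be the next thing to compare with it.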